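Ester in place of the primary amide on a shared core

The compounds below may be only part of what the source reports. "The series", "measured", "known", "first", "only" and "open" are said of these compounds alone.

Of the compounds shown here, three on one core have been measured in an ADME assay on microsomes from liver (Homo sapiens) for metabolic stability, read by LC-MS, using NADPH, with a stated time of 45 min, tested at 1 uM; on this read-out lower numbers stand for a shorter-lived compound and higher numbers for a longer-lived compound. Compound 1 `Cc1cc(/C=C/C#N)cc(C)c1Oc1cc(Nc2ccc(C#N)cc2)c(N)cc1C(=O)NN` gives 0.6 h. Compound 2 `Cc1cc(/C=C/C#N)cc(C)c1Oc1cc(Nc2ccc(C#N)cc2)c(N)cc1C(N)=O` gives 1.5 h, and compound 3 `Cc1cc(/C=C/C#N)cc(C)c1Oc1cc(Nc2ccc(C#N)cc2)c(N)cc1C(=O)N1CC1` gives 2.63 h. Compound 2 thus holds the second highest of the three numbers; its nearest neighbour is compound 3, with a step of a 1.8-fold higher number from compound 2 to compound 3 (0.24 log units; within the scatter), and its furthest is compound 1, with a step of a 2.5-fold higher number from compound 1 to compound 2 (0.40 log units; beyond the scatter).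

Compound 4 `COC(=O)c1cc(N)c(Nc2ccc(C#N)cc2)cc1Oc1c(C)cc(/C=C/C#N)cc1C` differs from compound 2 in one place: methoxy in place of amino on a carbonyl carbon. Among the measured compounds shown here, two measured steps touch the same carbonyl carbon or the nitrogen attached to it. The step of a 2.5-fold higher number from compound 1 to compound 2 (0.40 log units; beyond the scatter) and the step of a 1.8-fold higher number from compound 2 to compound 3 (0.24 log units; within the scatter) both move upward, though only the first goes beyond the scatter, and the larger step of a 4.4-fold higher number from compound 1 to compound 3 (0.64 log units; beyond the scatter) spans the two. For the measured compounds named here, none of them exchanges the amino group for methoxy, so no measured step matches the present change directly. On this basis the number for compound 4 is expected to stay near that of compound 2, with the step of a 1.3-fold lower number from compound 2 to compound 4 (0.10 log units; within the scatter) not reaching beyond the scatter. Compound 4 is therefore estimated at 1.2 h, within a range from 0.5 h to 3 h.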

Compound 4, half-life: 0.308 h
Beside the measured number, compound 4's estimate is 3.9-fold (0.59 log units) above it; the whole stated range lies above it.
By their numbers in this assay, from the lowest: compounds 4 and 1 (each within the scatter of the next); then compounds 2 and 3 (each within the scatter of the next).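

In this assay every earlier change at this carbonyl carbon had kept a nitrogen attached to it, and compound 4 now shows what happens when methoxy takes that place: the exchange for amino gives a 4.9-fold lower number from compound 2 to compound 4 (0.69 log units; beyond the scatter) and the exchange for aziridin-1-yl gives an 8.5-fold lower number from compound 3 to compound 4 (0.93 log units; beyond the scatter), both beyond the scatter. Set against the aminoamino group, the same exchange gives a 1.9-fold lower number from compound 1 to compound 4 (0.29 log units; within the scatter), which stays within the scatter, so on this read-out the methoxy compound cannot be told apart from compound 1 and stands clearly apart from the amino and aziridin-1-yl compounds. Nothing available here bears on why the carbonyl substituent shifts the half-life in this way.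

The compounds shown leave open whether a longer chain on the oxygen, such as ethoxy, or a carboxylic acid at this carbonyl carbon would fall with compound 4 or with compound 2. They also leave open whether a methylamino or dimethylamino group in the same place would stay with compound 2 and compound 3, which would show how far the higher numbers extend among other nitrogen groups.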